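Homologation of the pyrrolidine amide in a chemokine receptor series

The compounds below may be only part of what the source reports. "The series", "measured", "known", "first", "only" and "open" are said of these compounds alone.

Measured compounds:
compound 1, `Cc1nn([C@H](C)c2ccc(Cl)cc2Cl)c2nc(N3CC[C@H](N4CCC[C@H]4C(N)=O)[C@H](C)C3)cnc12`, 170 nM
compound 2, `CC(c1ccc(Cl)cc1Cl)n1ncc2ncc(N3CCC(N4CCCCC4)CC3)nc21`, 2580 nM
compound 3, `C[C@@H]1CC(c2cnc3c(C#N)nn([C@H](C)c4ccc(Cl)cc4Cl)c3n2)=CC[C@@H]1N1CCC[C@H]1C(C)(C)O`, 384 nM

In a functional assay on cells for antagonist activity at C-C chemokine receptor type 4 (Homo sapiens), read by fluorescence and calcium flux, with stated times of 2.5 s and 45 s (on this read-out higher numbers stand for weaker inhibition and lower numbers for stronger inhibition), compound 1 gives 170 nM, the lowest number of the three measured compounds. The nearest of the others is compound 3 at 384 nM; that gap lies beyond the usual scatter of this assay. Compound 2 stands furthest away at 2580 nM, again well beyond the scatter. Compounds 2 and 3 differ from compound 1 in several places at once, so their numbers show only where compound 1 stands and not which single change carries the difference.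

The next compound, compound 4, `Cc1nn([C@H](C)c2ccc(Cl)cc2Cl)c2nc(N3CC[C@H](N4CCC[C@H]4CCC(N)=O)[C@H](C)C3)cnc12`, keeps the core of compound 1 and changes one group: 2-carbamoylethyl in place of carbamoyl on a saturated ring carbon. The same difference, cut one bond further out, reads 2-carbamoylpyrrolidin-1-yl to 2-(2-carbamoylethyl)pyrrolidin-1-yl. Among the measured compounds shown here, no measured pair shows this change, so the size of the step is not known from the data. Moving the carbamoyl two carbons out from the ring is expected to cost some inhibition, though the step from compound 1 to compound 4 may stay within the scatter; the estimate is a 1.8-fold higher number from compound 1 to compound 4 (0.25 log units; within the scatter). For compound 4 the expected value in this assay is 300 nM, with a range from 110 nM to 850 nM.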

Compound 4, half-maximal inhibitory concentration: 37 nM
Beside the measured number, compound 4's estimate is 8.1-fold (0.91 log units) above it; the measured number lies below the stated range.
By their numbers in this assay, from the lowest: compound 4; then compound 1; then compound 3; then compound 2.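

In this assay, among the compounds shown here, replacing carbamoyl with 2-carbamoylethyl on a saturated ring carbon of the five-membered non-aromatic ring gives a 4.6-fold lower number from compound 1 to compound 4 (0.66 log units; beyond the scatter), the first step that can be read at a single place. The earlier compounds shown here could show only where compound 1 stands, whereas this pair shows that the position accepts a longer substituent and that the carbamoyl need not sit directly on the ring carbon for inhibition to improve on the core of compound 1. No available evidence bears on the origin of this step.

The pair leaves open whether the gain belongs to the added chain itself or to the chain together with its terminal carbamoyl, a question that a carboxylic acid or an amine at the end of the same chain would address. Also unresolved is how the number responds to chain length on either side of 2-carbamoylethyl, as with carbamoylmethyl or 3-carbamoylpropyl, and whether the step carries over to other substituents on the shared core.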